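Swapping acetamido for hydroxy on the shared core

The compounds below may be only part of what the source reports. "The series", "measured", "known", "first", "only" and "open" are said of these compounds alone.

Measured in a functional assay on HT-29 cells (Homo sapiens) for cytotoxicity; on this read-out higher numbers stand for weaker inhibition and lower numbers for stronger inhibition:
Compound 1 `CC(=O)Nc1[nH]nc2nnc(-c3ccccc3)c(-c3ccccc3)c12`: > 100000 nM (a limit)
Compound 2 `CC(=O)Nc1nn(C(C)=O)c2nnc(-c3ccccc3)c(-c3ccccc3)c12`: > 100000 nM (a limit)

Neither reading is a number, and both are limits of the assay. Compound 1 stands at the limit of > 100000 nM in this assay, at which 2 of the 2 values shown sit, and so has no exact value on this read-out.

Compound 3 `Oc1[nH]nc2nnc(-c3ccccc3)c(-c3ccccc3)c12` has not yet been measured. It keeps the core of compound 1 and changes one group: hydroxy in place of acetamido on an aromatic carbon. Hydroxy stands in place of acetamido on an aromatic carbon of a five-membered aromatic ring with 2 nitrogen.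

Within the data shown here, no measured step shows what a change of this kind does. In this assay the expected step is none beyond the scatter, in either direction. Among the measured compounds shown here, this expectation rests on compound 1 and its limit (> 100000 nM), the only anchor for the step. The estimated step is a number no higher from compound 1 to compound 3 (the limit leaves the size open), and compound 3 may well be reported only as a limit too. For compound 3 the expected value is 100000 nM, with an estimated range from 40000 nM to 200000 nM (the span in which most repeat measurements should fall).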

Compound 3, half-maximal inhibitory concentration: > 100000 nM
Compound 3 gave a limit, no number; the forecaster's own chance of this, stated with the estimate: 70%; the middle value sits exactly at the limit.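

In this assay compound 3 gives > 100000 nM as a limit of the assay and not a number. No step from compound 1 to compound 3 can be read, because both compounds stand at a limit: the limit of > 100000 nM in this assay, at which 3 of the 3 values shown sit.

The compounds shown leave open whether hydroxy in place of acetamido changes inhibition at all, and what exact value any of them would give.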